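The source may report more compounds than this note shows. Statements on the series, on what has been measured and on what is new or still open speak of the compounds shown alone.

Measured so far:
- compound 1 `Cc1[nH]c2ccccc2c(=O)c1Cc1ccccc1` gives 10000 nM
- compound 2 `Cc1c(Cc2ccccc2)c(=O)c2cc(Cl)ccc2n1C` gives 2000 nM
- compound 3 `CCCCCCCc1c(C)[nH]c2cc(OC)c(Cl)cc2c1=O` gives < 2000 nM

These three compounds were examined in a physicochemical assay for solubility, read by HPLC, at pH 7.4; a higher number here means a more soluble compound, a lower number a less soluble compound. Compound 1 reaches 10000 nM and compound 2 reaches 2000 nM. For compound 3 the result is a limit of the assay, < 2000 nM, and not a number; it therefore stands at the limit noted in the limit of < 2000 nM in this assay, at which 1 of the 3 values shown sits, at the lower end of what the three compounds show.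

Compound 4 `C=C(CCCCC)c1c(C)[nH]c2cc(OC)c(Cl)cc2c1=O` has not yet been measured in this assay. The change from compound 3 to compound 4 is a group of 7 heavy atoms (7 carbon; no ring) in place of a group of 7 heavy atoms (7 carbon; no ring), on an aromatic carbon. The group leaving and the group entering match in heavy-atom count and in their lack of donors and acceptors, so no step beyond the usual scatter is expected from compound 3 to compound 4 in this assay: the expected step is a step that the limit leaves unreadable from compound 3 to compound 4. Compound 4 is accordingly estimated at 1500 nM, in a range from 400 nM to 4000 nM, with a real chance that the assay again reports only a limit.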

Compound 4, solubility: 2000 nM
Estimate against measurement, compound 4: 1.3-fold (0.12 log units) below; measured number inside the range.
By their numbers in this assay, from the lowest: compounds 2 and 4 (each within the scatter of the next); then compound 1.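

In this assay, setting the chain with 1 double bond outside aromatic rings in place of heptyl on this aromatic carbon gives a number no lower from compound 3 to compound 4 (the limit leaves the size open). The result for compound 3, < 2000 nM, is a limit of the assay and not a number. Compound 4, at 2000 nM, gives this position a number for a chain of this heavy-atom count. The size of the step cannot be read because of the limit for compound 3: the limit of < 2000 nM in this assay, at which 1 of the 4 values shown sits.

The compounds shown leave open how the number at this position moves with a shorter chain, a longer chain, or a chain carrying an amine or a carboxylic acid. Also open, on these data alone, is whether the double bond changes the number at all, and a saturated chain with a measured number at this position would settle it.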